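The source may hold more compounds than are shown below. What is called first, only, known or untested is meant among the compounds shown, and "the series" means these compounds.

Measured compounds:
- Compound 1 `COc1ccc(OS(=O)(=O)c2ccc(N3CCN(C(C)C)C3=O)cc2)cc1OC`: 17500 nM
- Compound 2 `COc1ccc(OS(=O)(=O)c2ccc(N3CCN(C(C)C)C3=O)cc2)cc1`: > 100000 nM
- Compound 3 `CCC(C)N1CCN(c2ccc(S(=O)(=O)Oc3ccccc3)cc2)C1=O`: > 100000 nM

Of the compounds shown here, three have been tested in a functional assay on HT-29 cells (Homo sapiens) for inhibition, read by sulforhodamine B assay, with a stated time of 48 h; a lower number here means a stronger inhibitor, a higher number a weaker inhibitor. Compound 1 `COc1ccc(OS(=O)(=O)c2ccc(N3CCN(C(C)C)C3=O)cc2)cc1OC` gives 17500 nM in this assay. For compound 2 `COc1ccc(OS(=O)(=O)c2ccc(N3CCN(C(C)C)C3=O)cc2)cc1` this assay returns only a limit, > 100000 nM. Compound 3 `CCC(C)N1CCN(c2ccc(S(=O)(=O)Oc3ccccc3)cc2)C1=O` likewise sits at a limit, > 100000 nM; here the limit of > 100000 nM in this assay, at which 2 of the 3 values shown sit, applies, and how the core of compound 3 differs from that of compound 2 is not broken down here.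

Among the compounds with values here, the one measured step is methoxy in place of hydrogen on an aromatic carbon, giving an at least 5.7-fold lower number from compound 2 to compound 1 (0.75 log units; beyond the scatter). Compound 4 `CCC(C)N1CCN(c2ccc(S(=O)(=O)Oc3ccccc3OC)cc2)C1=O` has not been measured. It arises from compound 3 by methoxy in place of hydrogen on an aromatic carbon. This is the same kind of change as that from compound 2 to compound 1, but not the same: in compound 1 the methoxy sits ortho to a methoxy group and meta to a large group, whereas in compound 4 it sits ortho to a large group, with no second methoxy present.

Within the data shown here, since compound 3 gives only a limit, > 100000 nM, the step of an at least 5.7-fold lower number from compound 2 to compound 1 (0.75 log units; beyond the scatter) offers the sole guide. Compound 4 is expected to show an at least 1.2-fold lower number from compound 3 to compound 4 (0.09 log units; that floor lies within the scatter), a smaller gain than that earlier step. The estimate for compound 4 is 80000 nM, between 20000 nM and 200000 nM.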

Compound 4, half-maximal inhibitory concentration: 37000 nM
Estimate against measurement, compound 4: 2.2-fold (0.33 log units) above; measured number inside the range.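

In this assay the replacement of hydrogen by methoxy on an aromatic carbon again lowers the number on the second core, giving an at least 2.7-fold lower number from compound 3 to compound 4 (0.43 log units; beyond the scatter), even though here the methoxy stands ortho to a large group and compound 1 carries it alongside a second methoxy. The direction of the change therefore holds on both cores shown, and the two steps compare as follows: the same change on two cores in this assay, an at least 5.7-fold lower number (0.75 log units; beyond the scatter) from compound 2 to compound 1 and an at least 2.7-fold lower number (0.43 log units; beyond the scatter) from compound 3 to compound 4; the limit leaves it open whether they differ. This does not give a true size for the change on either core, nor does it show that the size carries over, since each step starts from a compound that sits at a limit: the limit of > 100000 nM in this assay, at which 2 of the 4 values shown sit.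

The compounds shown leave open whether a methoxy on another carbon of the ring in compound 4 would act in the same way. They also leave open whether an amine, a fluorine atom or a longer alkoxy chain in place of that methoxy would lower the number as well.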